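Working notes: replacing the sulfonamide substituent of compound 1

This account rests on a few compounds, and the source may have more. Where it says the series, first, only, none or still open, it means among the compounds named here.

Measured so far in a functional assay on SK-OV-3 cells (Homo sapiens) for antiproliferative activity, read by sulforhodamine B assay, with a stated time of 72 h (a higher number here means a weaker inhibitor, a lower number a stronger inhibitor), as follows
- compound 1 `Cc1cc(C)nc(NS(=O)(=O)c2ccc(Nc3nncc4ccccc34)cc2)n1` gives 0.08 nM
- compound 2 `O=C1CS/C(=N/Nc2nncc3ccccc23)N1` gives 0.8 nM
- compound 3 `Fc1ccc(Nc2nncc3ccccc23)cc1` gives 0.06 nM

Compound 1 stands within the scatter of compound 3, so these two cannot be ranked. The number for compound 2 lies higher than that of compound 1 and beyond the scatter, which makes compound 2 the weaker inhibitor of that pair.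

The next compound is compound 4 `O=S(=O)(Nc1ccccn1)c1ccc(Nc2nncc3ccccc23)cc1`, not yet measured. It carries pyridin-2-yl in place of 4,6-dimethylpyrimidin-2-yl on a sulfonamide nitrogen, and the rest of compound 1 is unchanged.

Within the data shown here, no two measured compounds differ in one place, so this change has no direct precedent in the data. Compound 3, at 0.06 nM, has no sulfonamide at all, yet it stays within the scatter of compound 1, at 0.08 nM, and this is the only support for expecting little change. With three compounds, that support is thin.

The expected 1.3-fold higher number from compound 1 to compound 4 (0.10 log units; within the scatter) is estimated to stay within the scatter in this assay, with no firm direction. For compound 4 the estimated value is 0.1 nM, with an expected range of 0.03 nM to 0.4 nM.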

Compound 4, half-maximal inhibitory concentration: 0.9 nM
Beside the measured number, compound 4's estimate is 9.0-fold (0.95 log units) below it; measured number above the stated range.
By their numbers in this assay, from the lowest: compounds 3 and 1 (each within the scatter of the next); then compounds 2 and 4 (each within the scatter of the next).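

In this assay the substituent on the sulfonamide nitrogen proves to matter: pyridin-2-yl in place of 4,6-dimethylpyrimidin-2-yl gives an 11-fold higher number from compound 1 to compound 4 (1.05 log units; beyond the scatter) and makes compound 4 the weaker inhibitor of the pair. Among these compounds, this is the first step that differs in one place, and the earlier compounds offered no such reading of this position. The entering group has 6 heavy atoms against 8 and 1 hydrogen-bond acceptor against 2, one ring hetero atom fewer, yet no measurement available here accounts for the step or assigns it to any one of these differences.

Among the compounds shown here, the single step leaves open whether the weaker inhibition follows the loss of the methyl groups or of the ring nitrogen, and an unsubstituted pyrimidin-2-yl or a 4,6-dimethylpyridin-2-yl group on the same sulfonamide nitrogen would separate the two. Also open, from the compounds shown here alone, is whether this nitrogen needs an aromatic ring at all, a question that a plain methyl, a longer alkyl chain or a saturated ring such as piperidine in that place would address.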